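Compound 3: a second chloro on the 4-chlorophenyl

This account rests on a few compounds, and the source may have more. Where it says the series, first, only, none or still open, it means among the compounds named here.

The series is built on the core shared by compound 1 `O=C(/C=C/c1ccc(Cl)cc1)c1cccc(NC(=O)c2cc(-c3ccncc3)n[nH]2)c1` and compound 2 `O=C(/C=C/c1ccco1)c1cccc(NC(=O)c2cc(-c3ccncc3)n[nH]2)c1`. In a functional assay, read by spectrophotometry, tested at 100 uM (a lower number here means a stronger inhibitor, a higher number a weaker inhibitor), compound 1 gives 63900 nM; compound 2 gives 41800 nM, and the two are separated only by a step within the scatter, so neither can be placed ahead of the other. That single measured step, a 1.5-fold lower number from compound 1 to compound 2 (0.18 log units; within the scatter), swaps the whole 4-chlorophenyl for furan-2-yl.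

Compound 3 `O=C(/C=C/c1ccc(Cl)cc1Cl)c1cccc(NC(=O)c2cc(-c3ccncc3)n[nH]2)c1` differs from compound 1 by chloro in place of hydrogen on an aromatic carbon. Going by the values given here, no measured step adds or removes one chloro on this ring; the one step in hand, a 1.5-fold lower number from compound 1 to compound 2 (0.18 log units; within the scatter), exchanges the ring itself and is too different to carry over, showing only that altering this end of the molecule moved the number by no more than the scatter. The expectation in this assay is therefore a step of no more than the scatter, a 1.2-fold lower number from compound 1 to compound 3 (0.07 log units; within the scatter), in no preferred direction. For compound 3 the estimated value is 55000 nM, with a range from 22000 nM to 140000 nM; as these numbers sit near the top concentration tested, the assay may return only a limit.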

Compound 3, half-maximal inhibitory concentration: 35000 nM
For compound 3 the middle estimate is 1.6-fold (0.20 log units) above the measured one, and the stated range covers the measured number.
By their numbers in this assay, from the lowest: compounds 3, 2 and 1 (each within the scatter of the next).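

In this assay, going by these compounds alone, the chloro in place of hydrogen, on an aromatic carbon ortho to a large group and meta to a chloro group, gives the first direct reading at this position: a 1.8-fold lower number from compound 1 to compound 3 (0.26 log units; within the scatter) and so no change that can be told from repeat measurement. The 2,4-dichlorophenyl end also cannot be separated from the furan-2-yl end, with a 1.2-fold lower number from compound 2 to compound 3 (0.08 log units; within the scatter), so the added chloro and the exchange of the whole ring both leave compound 3 level with its neighbours. No independent measurement is available to explain these results.

Compound 1, compound 2 and compound 3 all lie within the scatter of one another, so neither a single added chloro nor a ring exchange at this end of the molecule has yet produced a step that can be read as real. Going by these compounds, it remains open whether an amine or a carboxylic acid on this aromatic ring, in place of the chloro, would move the number in this assay beyond the scatter.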